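The source may hold more compounds than are shown below. What is called first, only, known or untested is meant among the compounds shown, and "the series" means these compounds.

Working notes on the series. Among the compounds with values here, in an ADME assay on RAW264.7 cells (Mus musculus) for cytotoxicity, read by trypan blue exclusion, with a stated time of 48 h (on this read-out higher numbers stand for weaker inhibition of growth and lower numbers for stronger inhibition of growth), compound 2 `Cc1cc(CN2CCN(C3C[C@@H]4CC[C@H]3C4)CC2)c(C)n1-c1ccc(Cl)cc1` gives 5.6 ug/mL, the lowest of the three numbers so far. Compound 1 `Cc1cc(CNOCc2ccccc2)c(C)n1-c1ccc(Cl)cc1` gives 133 ug/mL and compound 3 `Cc1c(CN2CCN(c3ccccc3)CC2)c(CN2CCN(c3ccccc3)CC2)c(C)n1-c1ccc(Cl)cc1` gives 500 ug/mL, and both stand above compound 2 by more than the scatter.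

The next compound to be read is compound 4 `Cc1cc(CN2CCN(C3CCCCC3)CC2)c(C)n1-c1ccc(Cl)cc1`. It keeps the shared core of compound 2 and changes one group, on an amine nitrogen in a ring, where cyclohexyl enters: a group of 6 heavy atoms (6 carbon; one six-membered non-aromatic ring of carbon only) in place of a group of 7 heavy atoms (7 carbon; 2 five-membered non-aromatic rings of carbon only), on an amine nitrogen in a ring. Both groups are made of carbon only and are of similar size.

Within the data shown here, no pair of measured compounds differs in one place, so the data show no direct precedent for this kind of step. Compound 1 and compound 3 differ from compound 2 in more than this one group, so they give little guide to its size. The closest reference is therefore compound 2 at 5.6 ug/mL, and compound 4 is expected to stay near it in this assay. A small upward move, not beyond the scatter, is the expectation, and the estimated change is a 1.6-fold higher number from compound 2 to compound 4 (0.21 log units; within the scatter).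

For compound 4 the expected value is 9 ug/mL, with an estimated range from 3.5 ug/mL to 30 ug/mL.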

Compound 4, concentration for 50% growth inhibition: 5.5 ug/mL
Compound 4: middle estimate off by 1.6-fold (0.21 log units), on the high side; the range from low to high includes it.
By their numbers in this assay, from the lowest: compounds 4 and 2 (each within the scatter of the next); then compound 1; then compound 3.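

In this assay, within the data shown here, the first step that differs in one place gives a 1.0-fold lower number from compound 2 to compound 4 (0.01 log units; within the scatter), so the series now has a direct reading at this position, on an amine nitrogen in a ring. Across this step, a group of 7 carbon atoms with 2 five-membered non-aromatic rings and 2 defined stereocentres and a cyclohexyl group with one six-membered non-aromatic ring and no stereocentre give numbers within the scatter of each other, so neither the second ring nor the defined stereocentres are needed for a number at the level of compound 2 in this read-out. Nothing measured on these compounds bears on why the two carbon-only groups read alike.

Both groups in this step are carbon-only rings of similar size, so the compounds shown do not tell how far this level extends to a smaller group such as methyl, or to groups carrying other atoms, such as acetyl, a hydroxyethyl chain or a carboxylic acid. They also leave open how the other stereoisomers of the group in compound 2 would read.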